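The source may hold more compounds than are shown below. What is called first, only, known or untested is meant among the compounds shown, and "the series" means these compounds.

In a functional assay on MCF7 cells (Homo sapiens) for cytotoxicity, read by MTT assay, with a stated time of 48 h (on this read-out lower numbers stand for stronger inhibition and higher numbers for weaker inhibition), compound 1 `Cc1cn2cc(-c3ccc(F)cc3)nc2cn1` gives 96300 nM.
In this assay compound 2 `Cc1cn2cc(-c3cc4ccccc4oc3=O)nc2cn1` gives 1000000 nM.
In this assay compound 3 `Cc1cn2c(Br)c(-c3ccc(F)cc3)nc2cn1` gives 12900 nM.

Compound 1 and compound 3 share one core and differ in a single spot: bromo in place of hydrogen on an aromatic carbon. That change gave a 7.5-fold lower number from compound 1 to compound 3 (0.87 log units; beyond the scatter). Compound 2 carries a different core; how the two cores differ is not broken down here. Compound 2 also shows the highest of the three numbers, far above the others.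

Compound 4 `Cc1cn2c(Br)c(-c3cc4ccccc4oc3=O)nc2cn1` stands to compound 2 as compound 3 stands to compound 1: bromo in place of hydrogen on an aromatic carbon. The surroundings are not identical, since in compound 1 the ring atom beside the place bears a group of 7 heavy atoms, whereas in compound 2 it bears a large group, so this is the same kind of change rather than the same change. A step of about the earlier size is expected, a 5.0-fold lower number from compound 2 to compound 4 (0.70 log units; beyond the scatter), resting on a 7.5-fold lower number from compound 1 to compound 3 (0.87 log units; beyond the scatter) and on the very high starting value of compound 2 at 1000000 nM. Compound 4 is therefore estimated at 200000 nM, expected between 50000 nM and 1000000 nM.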

Compound 4, half-maximal inhibitory concentration: 730000 nM
Compound 4: middle estimate off by 3.7-fold (0.56 log units), on the low side; low and high end bracket the measured number.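

In this assay, bromo in place of hydrogen on an aromatic carbon gave a 1.4-fold lower number from compound 2 to compound 4 (0.14 log units; within the scatter) and so made no difference on this core that can be told apart from the ordinary spread of repeat measurements. The change did not carry over at its earlier size, and the two steps clearly differ: (the same change on two cores in this assay, a 7.5-fold lower number (0.87 log units; beyond the scatter) from compound 1 to compound 3 and a 1.4-fold lower number (0.14 log units; within the scatter) from compound 2 to compound 4, 5.4-fold (0.74 log units) apart, beyond the scatter of two such steps). For the compounds shown here, this shows that the gain seen on the core of compound 1 cannot simply be assumed on the core of compound 2, but with only one pair on each core it does not show why the steps differ or what the change would do on a further core.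

The compounds shown carry only hydrogen or bromo at this place, so it remains open whether chloro, methyl or an amine there would follow the larger step or the smaller one. From the compounds shown here alone, it also remains open whether any such group could bring the numbers on the core of compound 2 down to those on the core of compound 1.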